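Acetylprolyl Replaces Piperazinylmethyl on the Shared Amide

A few compounds are considered here, and "the series" means these few. Any claim that something is new, unique, unknown or untested is made for them only; others in the source may bear on it.

Of the compounds shown here, three built on the shared core have been measured in a functional assay on U2OS cells for antagonist activity at proto-oncogene Wnt-3 (Homo sapiens), read by a luciferase reporter, with a stated time of 18 h; on this read-out lower numbers stand for an effect already at smaller amounts and higher numbers for an effect only at larger amounts of compound. Compound 1 `O=C(CN1CCCC1)N1CCC(NS(=O)(=O)c2cc(S(=O)(=O)c3ccccc3)ccc2C(F)(F)F)CC1` gives 190 nM, compound 2 `O=C(CN1CCNCC1)N1CCC(NS(=O)(=O)c2cc(S(=O)(=O)c3ccccc3)ccc2C(F)(F)F)CC1` gives 250 nM, and compound 3 `CC(C)(C)OC(=O)N1CCC[C@H]1C(=O)N1CCC(NS(=O)(=O)c2cc(S(=O)(=O)c3ccccc3)ccc2C(F)(F)F)CC1` gives 60 nM. Compound 2 stands at the high end of these numbers, yet the gap separating it from its nearest neighbour is small (a 1.3-fold higher number from compound 1 to compound 2 (0.12 log units; within the scatter)), whereas compound 3 sits clearly apart (a 4.2-fold lower number from compound 2 to compound 3 (0.62 log units; beyond the scatter); seen from compound 1, a 3.2-fold lower number from compound 1 to compound 3 (0.50 log units; beyond the scatter)).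

Compound 4 `CC(=O)N1CCC[C@H]1C(=O)N1CCC(NS(=O)(=O)c2cc(S(=O)(=O)c3ccccc3)ccc2C(F)(F)F)CC1` is not yet measured. Its difference from compound 2 is 1-acetylpyrrolidin-2-yl in place of (piperazin-1-yl)methyl on a carbonyl carbon. Going by the values given here, the step from compound 2 to compound 3 bears most directly on it, since both replace (piperazin-1-yl)methyl by a substituted pyrrolidin-2-yl on the same carbonyl carbon; compound 4 carries an acetyl rather than a tert-butoxycarbonyl on that ring nitrogen, and no measured pair shows what that exchange alone does. In this assay a lower number is therefore expected for compound 4, in the same direction as the move to compound 3 but with less certainty about its size, so the expected step is a 2.8-fold lower number from compound 2 to compound 4 (0.44 log units; beyond the scatter). Compound 4 is estimated at 90 nM, with a range from 40 nM to 220 nM.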

Compound 4, half-maximal effective concentration: 250 nM
For compound 4 the middle estimate is 2.8-fold (0.44 log units) below the measured one; the whole stated range lies below it.
By their numbers in this assay, from the lowest: compound 3; then compounds 1, 2 and 4 (each within the scatter of the next).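

In this assay the substituted pyrrolidin-2-yl ring on the carbonyl carbon does not alone bring the lower number seen for compound 3, since keeping that ring and putting methyl in place of tert-butoxy on the carbonyl carbon gives a 4.2-fold higher number from compound 3 to compound 4 (0.62 log units; beyond the scatter). Set against the earlier side chains, 1-acetylpyrrolidin-2-yl in place of (piperazin-1-yl)methyl gives no change at the digits printed from compound 2 to compound 4 (within the scatter), and the same group in place of (pyrrolidin-1-yl)methyl gives a 1.3-fold higher number from compound 1 to compound 4 (0.12 log units; within the scatter), so compound 1, compound 2 and compound 4 stay together while compound 3 alone stands apart. No evidence is available on why the exchange at this ring nitrogen has this effect.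

The compounds shown leave open whether the lower number of compound 3 belongs to the tert-butoxy group itself or would also appear with another carbamate, such as methoxycarbonyl or benzyloxycarbonyl, or with a pivaloyl group, which keeps the tert-butyl carbons without the ester oxygen. Also open, on these data alone, are what a free secondary amine at that ring nitrogen would give and what the opposite configuration at the defined stereocentre would give.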